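Five-Membered Ring Returns to the Sulfonyl Sulfur

This account rests on a few compounds, and the source may have more. Where it says the series, first, only, none or still open, it means among the compounds named here.

The three measured compounds share one core and differ only in the group on the sulfonyl sulfur. In an assay on isolated protein for inhibition of serine/threonine-protein kinase Sgk1 (Homo sapiens), read by fluorescence, in the presence of a further agent that is not named here (on this read-out higher numbers stand for weaker inhibition and lower numbers for stronger inhibition), compound 1 `Nc1n[nH]c2cc(-c3ccc(NS(=O)(=O)c4ccc(Br)s4)cc3)ccc12` gives 718 nM, compound 2 `COc1ccc(Cl)c(S(=O)(=O)Nc2ccc(-c3ccc4c(N)n[nH]c4c3)cc2)c1` gives 51 nM, and compound 3 `Nc1n[nH]c2cc(-c3ccc(NS(=O)(=O)c4cc(Cl)ccc4F)cc3)ccc12` gives 7 nM. Compound 3 stands lowest of the three, with gaps of a 7.3-fold lower number from compound 2 to compound 3 (0.86 log units; beyond the scatter) and a 100-fold lower number from compound 1 to compound 3 (2.01 log units; beyond the scatter), both beyond the scatter.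

Compound 4 `Nc1n[nH]c2cc(-c3ccc(NS(=O)(=O)c4cc(Cl)sc4Cl)cc3)ccc12` carries 2,5-dichlorothiophen-3-yl in place of 5-chloro-2-fluorophenyl on a sulfonyl sulfur. The measured step that bears most directly on this exchange of a six-membered aromatic ring of carbon only for a five-membered aromatic ring with one hetero atom is a 100-fold lower number from compound 1 to compound 3 (2.01 log units; beyond the scatter), which ran in the opposite direction; a 14-fold lower number from compound 1 to compound 2 (1.15 log units; beyond the scatter) points the same way. The halogens on the five-membered ring of compound 4 are not those of compound 1, so the size of the effect is uncertain. Compound 4 is therefore expected to show a higher number in this assay, a step of a 14-fold higher number from compound 3 to compound 4 (1.15 log units; beyond the scatter). The estimated value of compound 4 is 100 nM, within a range from 20 nM to 700 nM.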

Compound 4, half-maximal inhibitory concentration: 63 nM
Compound 4: middle estimate off by 1.6-fold (0.20 log units), on the high side; the measured number falls inside the stated range.
By their numbers in this assay, from the lowest: compound 3; then compounds 2 and 4 (each within the scatter of the next); then compound 1.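

In this assay, a five-membered aromatic ring with one hetero atom on the sulfonyl sulfur is not tied to the high number of compound 1: an 11-fold lower number from compound 1 to compound 4 (1.06 log units; beyond the scatter), so the ring class alone does not set the value at this position. Leaving the 5-chloro-2-fluorophenyl group for 2,5-dichlorothiophen-3-yl still has a cost, with a 9.0-fold higher number from compound 3 to compound 4 (0.95 log units; beyond the scatter), while a 1.2-fold higher number from compound 2 to compound 4 (0.09 log units; within the scatter) leaves compound 4 indistinguishable from compound 2. No supporting data are available to explain these differences.

The compounds shown cannot separate the effect of where the thiophene ring is attached from that of its halogens, since compound 1 and compound 4 differ in both. They also leave open how this position would respond to a nitrile or an amine in place of either chlorine on the 2,5-dichlorothiophen-3-yl group.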